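Swapping 3-fluorophenyl for 1H-indol-7-yl

This account rests on a few compounds, and the source may have more. Where it says the series, first, only, none or still open, it means among the compounds named here.

Of the compounds shown here, three built on a shared core have been tested in a functional assay on HepG2 cells (Homo sapiens) for cytotoxicity, read by spectrophotometry, with a stated time of 72 h; a higher number here means a weaker inhibitor, a lower number a stronger inhibitor. Compound 1 (`COc1cc(-n2c(-c3cccc(F)c3)cccc2=O)cc(OC)c1OC`) gives 159 nM, the lowest number of the three, which makes it the strongest inhibitor in this small set. Compound 2 (`COc1cc(-n2c(-c3ccc(OC(F)(F)F)cc3)cccc2=O)cc(OC)c1OC`) gives 1960 nM, and compound 3 (`COc1cc(-c2cccc(=O)n2-c2cc(OC)c(OC)c(OC)c2)cc(OC)c1OC`) gives 5460 nM. Both numbers are higher than that of compound 1 by more than the usual scatter of repeated measurements.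

Compound 4 (`COc1cc(-n2c(-c3cccc4cc[nH]c34)cccc2=O)cc(OC)c1OC`) has not been measured yet. It keeps the core of compound 1 but carries 1H-indol-7-yl in place of 3-fluorophenyl on an aromatic carbon, next to the ring nitrogen: 1H-indol-7-yl in place of 3-fluorophenyl on an aromatic carbon. Going by the values given here, no measured pair shows a change in one place alone, so there is no direct precedent for this swap. With compound 1 at 159 nM and compound 3 at 5460 nM, values in this set lie far apart, so the expected range must be wide. The expected result is a 1.3-fold higher number from compound 1 to compound 4 (0.10 log units; within the scatter), a step no larger than the scatter. For compound 4 the estimated value is 200 nM, with an expected range from 25 nM to 1500 nM.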

Compound 4, half-maximal inhibitory concentration: 2400 nM
Beside the measured number, compound 4's estimate is 12-fold (1.08 log units) below it; the measured number lies above the stated range.
By their numbers in this assay, from the lowest: compound 1; then compounds 2 and 4 (each within the scatter of the next); then compound 3.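

Going by these compounds alone, this is the first step in the set that changes one place alone. In this assay, putting 1H-indol-7-yl in place of 3-fluorophenyl on an aromatic carbon, next to the ring nitrogen, gives a 15-fold higher number from compound 1 to compound 4 (1.18 log units; beyond the scatter), so on this core the group at this position can strongly change the result, and this swap weakens inhibition. No measurement shown explains the rise.

The swap changes several things at once: it removes the fluorine and adds a five-membered ring with a hydrogen-bond donor, so this single step cannot show which of these matters. Also open, from the compounds shown here alone, is how the result would change with an unsubstituted phenyl, an amine or a carboxylic acid at this position.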